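The source may report more compounds than this note shows. Statements on the series, on what has been measured and on what is new or still open speak of the compounds shown alone.

In an ADME assay on BCBL1 cells (Homo sapiens) for cytotoxicity, with a stated time of 7 days (on this read-out higher numbers stand for lower toxicity in this test and lower numbers for higher toxicity in this test), compound 2 (`CC(C)Nc1nc(N)nc2c1ncn2/C=C1/CC1(CO)CO`) gives > 20000 nM as a limit of the assay, not a number. Compound 1 (`CCCCCCCCOc1nc(N)nc2c1ncn2/C=C1/CC1(CO)CO`) gives > 20000 nM as a limit too. Compound 2 therefore stands only at the limit of > 20000 nM in this assay, at which 2 of the 2 values shown sit, and has no exact value here. Compound 3 (`Nc1nc(NC2CC2)c2ncn(/C=C3/CC3(CO)CO)c2n1`) carries cyclopropyl in place of isopropyl on a nitrogen on an aromatic ring, a change counted as cyclopropyl in place of isopropyl on a nitrogen on an aromatic ring in the two structures. Within the data shown here, only one measured step bears on it, a step that the two limits leave unreadable from compound 1 to compound 2 with isopropylamino in place of octyloxy, and it has no readable size. Even that much larger swap left compound 2 without a number, so no change beyond the usual scatter is expected in this assay and no direction can be favoured. The expected change is a step that the limit leaves unreadable from compound 2 to compound 3 as an estimate only. Compound 3 is estimated at 25000 nM within an expected range of 10000 nM to 60000 nM in this test, and it may well be reported only as a limit.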

Compound 3, half-maximal cytotoxic concentration: 71500 nM
Compound 3: the middle estimate sits 2.9-fold (0.46 log units) below what was measured; measured number above the stated range.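

Neither step into compound 3, from compound 1 or from compound 2, can be read, because compound 1 and compound 2 have only a limit rather than a number: the limit of > 20000 nM in this assay, at which 2 of the 3 values shown sit.

The compounds shown leave open whether cyclopropyl in place of isopropyl changes the result at all in this assay.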